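The source may hold more compounds than are shown below. What is called first, only, known or untested is meant among the compounds shown, and "the series" means these compounds.

Measured compounds in a functional assay on HeLa cells (Homo sapiens) for inhibition, read by sulforhodamine B assay; a higher number here means a weaker inhibitor, a lower number a stronger inhibitor:
- compound 1, `Cc1ccc(NC2=CC(=O)c3c(nc4n3[C@H]3OC[C@@H](O)[C@H]3OC4)C2=O)cc1C`: 4320 nM
- compound 2, `O=C1C(NC2CC2)=CC(=O)c2c1nc1n2[C@H]2OC[C@@H](O)[C@H]2OC1`: a limit only, > 16000 nM
- compound 3, `COc1ccc(NC2=CC(=O)c3c(nc4n3[C@H]3OC[C@@H](O)[C@H]3OC4)C2=O)cc1`: a limit only, > 8000 nM

Going by the values given here, compound 1 carries the only number among the three; the other two sit at limits of this assay. Compound 3 stands at the limit of > 8000 nM in this assay, at which 1 of the 3 values shown sits. Compound 2 stands at the limit of > 16000 nM in this assay, at which 1 of the 3 values shown sits. The exchange of the amine substituent from compound 1 runs an at least 3.7-fold higher number from compound 1 to compound 2 (0.56 log units; beyond the scatter) and an at least 1.8-fold higher number from compound 1 to compound 3 (0.26 log units; that floor lies within the scatter); the pair of limits leaves a step that the two limits leave unreadable from compound 2 to compound 3. So every step among the measured compounds changes the same amine substituent, and no step between two aryl groups has a readable size.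

Compound 4, `CCOc1ccccc1NC1=CC(=O)c2c(nc3n2[C@H]2OC[C@@H](O)[C@H]2OC3)C1=O`, changes that same position: 2-ethoxyphenyl in place of 4-methoxyphenyl on an amine nitrogen. Among the compounds with values here, the steps that bear on it, from compound 1 to compound 3 and from compound 1 to compound 2, both led to limits, and the one aryl-to-aryl step is floored within the scatter. For this assay the expectation is therefore a step from compound 3 of no readable size, most likely again a limit, a step that the limit leaves unreadable from compound 3 to compound 4. Compound 4 is estimated at 11000 nM, within 3000 nM to 40000 nM.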

Compound 4, half-maximal inhibitory concentration: 8300 nM
Estimate against measurement, compound 4: 1.3-fold (0.12 log units) above; the measured number falls inside the stated range.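

In this assay, going by these compounds alone, compound 4 supplies the second actual number at this amine nitrogen, and a 1.9-fold higher number from compound 1 to compound 4 (0.28 log units; within the scatter) is the first readable step between two aryl groups, leaving 2-ethoxyphenyl and 3,4-dimethylphenyl unseparated. Against the cyclopropyl group the reading is an at least 1.9-fold lower number from compound 2 to compound 4 (0.28 log units; that floor lies within the scatter), so the clear gap seen for compound 1 over compound 2 is not established for compound 4, whose floor stays inside the scatter. Compound 3 remains a limit, so neither its step to compound 4 nor its step from compound 2 can be read: the limit of > 8000 nM in this assay, at which 1 of the 4 values shown sits.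

Compound 3 and compound 4 differ in both the name and the placement of the alkoxy group, so the shown data cannot say whether either one matters, or whether 4-methoxyphenyl truly differs from 2-ethoxyphenyl at all. A 2-methoxyphenyl or a 4-ethoxyphenyl group on the same nitrogen would split those two questions, and a benzyl group or a longer alkyl chain would show whether an aryl group attached directly to the nitrogen is needed for a readable number.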